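The source may hold more compounds than are shown below. What is called first, only, known or untested is meant among the compounds shown, and "the series" means these compounds.

Compound 1 `COC(=O)C[C@H](NC(=O)OC(C)(C)C)C(=O)N(Cc1ccccc1)C1(C(=O)NCc2ccccc2)CCN(Cc2ccccc2)CC1` gives > 100000 nM in an ADME assay on MDCK cells (Canis lupus familiaris) for cytotoxicity, read by microscopy, with a stated time of 72 h (a lower number here means that less compound is tolerated, a higher number that more compound is tolerated), and this value is a limit of the assay rather than a number.
Compound 2 `COC(=O)C[C@H](NC(=O)OC(C)(C)C)C(=O)N(Cc1ccc(C(F)(F)F)cc1)C1(C(=O)NCc2ccccc2)CCN(Cc2ccccc2)CC1` gives 84000 nM in this assay.
Compound 3 `COC(=O)C[C@H](NC(=O)OC(C)(C)C)C(=O)N(Cc1cccc(F)c1)C1(C(=O)NCc2ccccc2)CCN(Cc2ccccc2)CC1` gives 47000 nM in this assay.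

Compound 3 holds the lowest of the two numbers in hand; its nearest neighbour is compound 2, and the gap a 1.8-fold lower number from compound 2 to compound 3 (0.25 log units; within the scatter) lies within the scatter. Against compound 1, the step of an at least 2.1-fold lower number from compound 1 to compound 3 (0.32 log units; beyond the scatter) is beyond the scatter, whereas an at least 1.1-fold lower number from compound 1 to compound 2 (0.07 log units; that floor lies within the scatter) has a floor that lies within it.

Compound 4 `COC(=O)C[C@H](NC(=O)OC(C)(C)C)C(=O)N(Cc1ccc(F)c(F)c1)C1(C(=O)NCc2ccccc2)CCN(Cc2ccccc2)CC1` differs from compound 3 by fluoro in place of hydrogen on an aromatic carbon. The step that bears most on this change is an at least 2.1-fold lower number from compound 1 to compound 3 (0.32 log units; beyond the scatter), a modest lowering of the number; the step of an at least 1.1-fold lower number from compound 1 to compound 2 (0.07 log units; that floor lies within the scatter) also ran downward, though only at a floor within the scatter. A further fluoro is therefore expected to lower the number in this assay by at most a small step, a 1.6-fold lower number from compound 3 to compound 4 (0.19 log units; within the scatter). Compound 4 is accordingly estimated at 30000 nM, with a range from 14000 nM to 70000 nM.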

Compound 4, minimum cytotoxic concentration: 20000 nM
Beside the measured number, compound 4's estimate is 1.5-fold (0.18 log units) above it; the range from low to high includes it.
By their numbers in this assay, from the lowest: compound 4; then compounds 3 and 2 (each within the scatter of the next). At a limit, above all of these: compound 1.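

Placed ortho to a fluoro group and para to a large group, the added fluoro gives a 2.4-fold lower number from compound 3 to compound 4 (0.37 log units; beyond the scatter), so a second fluoro on this ring moves the number beyond the scatter, and 3,4-difluorobenzyl also separates clearly from 4-(trifluoromethyl)benzyl, with a 4.2-fold lower number from compound 2 to compound 4 (0.62 log units; beyond the scatter), where compounds 2 and 3 could not be told apart. Against the unsubstituted benzyl, the change reads an at least 5.0-fold lower number from compound 1 to compound 4 (0.69 log units; beyond the scatter), which is a floor and not a measured size. Compound 1 stands at a limit of the assay: the limit of > 100000 nM in this assay, at which 1 of the 4 values shown sits.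

The compounds shown leave open whether a fluoro at this place would lower the number without the fluoro already on the ring. They also leave open how a chloro, a methoxy or a nitrile at this place would read in this assay.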